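Shortening the dimethylamino chain in the sulfamate series

The source may hold more compounds than are shown below. What is called first, only, known or untested is meant among the compounds shown, and "the series" means these compounds.

Compound 2 `CN(C)CCCN(Cc1ccccc1)c1cccc(C(=O)N2CCc3ccc(OS(N)(=O)=O)cc3C2)c1` stands lowest of the two numbers in an assay on HEK293 cells for inhibition of Steryl-sulfatase (Homo sapiens), tested at 1 uM (a higher number here means a stronger effect of the compound at the concentration tested, a lower number a weaker effect), where compound 2 gives 26%. Its nearest neighbour is compound 1 `CCN(Cc1ccccc1)c1cccc(C(=O)N2CCc3ccc(OS(N)(=O)=O)cc3C2)c1`, which in this assay gives 69%; the step of a number 43 percentage points lower from compound 1 to compound 2 (beyond the scatter) is large and beyond the scatter. Compound 3 `CN(C)CCN(Cc1ccccc1)c1cccc(C(=O)N2CCc3ccc(OS(N)(=O)=O)cc3C2)c1` carries dimethylamino in place of (dimethylamino)methyl on a saturated chain carbon, two bonds along the chain from a nitrogen on an aromatic ring; the same difference, cut one bond further out, reads 3-(dimethylamino)propyl to 2-(dimethylamino)ethyl. For the measured compounds named here, only the step from compound 1 to compound 2 bears on this change: it shows that the longer chain carrying dimethylamino went with a large loss. Compound 3 sits between compound 1 and compound 2 in chain length, so an upward step in this assay is expected, but one step alone does not show how much of the loss the shorter chain recovers. For compound 3 the expected step is a number 16 percentage points higher from compound 2 to compound 3 (beyond the scatter). Compound 3 is estimated at 42%, with a range from 18% to 66%.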

Compound 3, a percentage reported as inhibition, at one concentration (the size of the read-out at that concentration, not a potency): 28.6%
Beside the measured number, compound 3's estimate is 13.4 percentage points above it, and the stated range covers the measured number.
By their numbers in this assay, from the lowest: compounds 2 and 3 (each within the scatter of the next); then compound 1.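

In this assay, the step of a number 2.6 percentage points higher from compound 2 to compound 3 (within the scatter) means that 2-(dimethylamino)ethyl and 3-(dimethylamino)propyl cannot be told apart at this position. The large loss also persists with the shorter chain, as a number 40.4 percentage points lower from compound 1 to compound 3 (beyond the scatter) shows, so it does not depend on the extra chain carbon of compound 2. Among these three compounds, the loss goes with dimethylamino on the chain, and the two chain lengths tested make no measurable difference. Nothing available here explains the loss.

On these data alone, it remains open whether a hydroxyl or methoxy group at the end of the same chain would match compound 1 or share the loss. A morpholine in place of dimethylamino, or a longer chain carrying dimethylamino, is equally unresolved.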